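This account rests on a few compounds, and the source may have more. Where it says the series, first, only, none or still open, it means among the compounds named here.

In a functional assay on the whole organism with Rattus norvegicus as the target (on this read-out higher numbers stand for an effect only at larger amounts of compound and lower numbers for an effect already at smaller amounts), compound 3 `CCCCc1ccc2c(c1)sc(=N)n2CC[S+]([O-])CC` gives no exact number: > 10 mg/kg is only a limit of the assay. Compound 4 `CC[S+]([O-])CCn1c(=N)sc2cc(OC(F)(F)F)ccc21` differs from compound 3 by a single swap, trifluoromethoxy in place of butyl on an aromatic carbon. Trifluoromethoxy is also carried by compound 1 `N=c1sc2cc(OC(F)(F)F)ccc2n1CC(N)=O`, which gives 7 mg/kg, and by compound 2 `N=c1sc2cc(OC(F)(F)F)ccc2n1CC[S+]([O-])c1ccccc1`, which gives 4.2 mg/kg. These two values lie within the usual scatter of each other. On the strength of compound 1 at 7 mg/kg and compound 2 at 4.2 mg/kg, a moderate step towards smaller amounts is expected in this assay. In numbers, the expected step is an at least 2.0-fold lower number from compound 3 to compound 4 (0.30 log units; that floor lies within the scatter). For compound 4 the estimated value is 5 mg/kg, with an expected range from 2 mg/kg to 12 mg/kg.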

Compound 4, dose for half-maximal effect: 1.2 mg/kg
Beside the measured number, compound 4's estimate is 4.2-fold (0.62 log units) above it; the whole stated range lies above it.
By their numbers in this assay, from the lowest: compound 4; then compounds 2 and 1 (each within the scatter of the next). At a limit, above all of these: compound 3.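

Trifluoromethoxy in place of butyl on the aromatic carbon gives an at least 8.3-fold lower number from compound 3 to compound 4 (0.92 log units; beyond the scatter), the first step read at this position in this assay. Compound 3 has only a limit, so that step has no upper end: the limit of > 10 mg/kg in this assay, at which 1 of the 4 values shown sits.

With trifluoromethoxy kept in place, the side chain matters too: ethyl in place of phenyl on the sulfur gives a 3.5-fold lower number from compound 2 to compound 4 (0.54 log units; beyond the scatter), and the sulfur-bearing group in place of the shorter group on the chain gives a 5.8-fold lower number from compound 1 to compound 4 (0.77 log units; beyond the scatter).

Still open, as far as these compounds go, is how a chlorine or a methoxy group on that aromatic carbon would read, and how a methyl or a longer chain on the sulfur would.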